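The source may report more compounds than this note shows. Statements on the series, on what has been measured and on what is new or still open speak of the compounds shown alone.

Of the compounds shown here, two have been measured in an in vitro functional assay on CHO/Galpha16 cells for antagonist activity at C-C chemokine receptor type 8 (Homo sapiens), read by FLIPR; a higher number here means a weaker inhibitor, a lower number a stronger inhibitor. Compound 1 `CCCC(=O)N1CCC(NS(=O)(=O)c2ccc(NC(=O)c3cccc(C)c3)c3ccccc23)CC1` gives 5.1 nM in this assay. Compound 2 `CCCC(=O)N1CCC(NS(=O)(=O)c2ccc(NC(=O)c3ccc(CC)cc3)c3ccccc23)CC1` gives 10.8 nM in this assay. Within the data shown here, of these two numbers, compound 2 holds the higher one, and the only measured step, a 2.1-fold higher number from compound 1 to compound 2 (0.33 log units; beyond the scatter), separates it from compound 1.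

Compound 3 `CCCC(=O)N1CCC(NS(=O)(=O)c2ccc(NC(=O)c3ccoc3)c3ccccc23)CC1` is not yet measured. It differs from compound 2 in one place: furan-3-yl in place of 4-ethylphenyl on a carbonyl carbon. Among the measured compounds shown here, the single measured step, a 2.1-fold higher number from compound 1 to compound 2 (0.33 log units; beyond the scatter), concerns a change from one substituted phenyl group to another on the same carbonyl carbon, so it shows only that this part of the molecule is tolerant of small changes and gives no direct guide to an exchange of the phenyl ring for a five-membered furan-3-yl ring. For the measured compounds named here, with no closer precedent, a step of modest size in either direction, or none beyond the scatter, is equally plausible, and the expectation is placed close to compound 2.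

The expected step is therefore a 1.3-fold higher number from compound 2 to compound 3 (0.11 log units; within the scatter). Compound 3 is estimated at 14 nM in this assay, with a likely range from 4 nM to 50 nM.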

Compound 3, half-maximal inhibitory concentration: 1520 nM
Estimate against measurement, compound 3: 110-fold (2.04 log units) below; measured number above the stated range.
By their numbers in this assay, from the lowest: compound 1; then compound 2; then compound 3.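

In this assay, the exchange of 4-ethylphenyl for furan-3-yl on this carbonyl carbon brings a 140-fold higher number from compound 2 to compound 3 (2.15 log units; beyond the scatter) and the exchange of 3-methylphenyl for furan-3-yl brings a 300-fold higher number from compound 1 to compound 3 (2.47 log units; beyond the scatter) in the same direction. Among these compounds, the only earlier comparison, a 2.1-fold higher number from compound 1 to compound 2 (0.33 log units; beyond the scatter) between two substituted phenyl groups, hinted at none of this, so the position accepts those two phenyl groups but is far from indifferent to what sits there. Furan-3-yl differs from both phenyl groups in ring size, in its ring oxygen and in carrying no alkyl group, and no measurement available here explains the loss of inhibition.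

The compounds shown leave open which of those differences matters, and a thiophen-3-yl ring, an unsubstituted phenyl ring or a methyl-substituted furan would help to separate them. Also open, as far as these compounds go, is how the position responds to other groups on the phenyl ring, such as a methoxy group or a chlorine atom.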